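Methyl on the ring amine nitrogen across two cores

The source may hold more compounds than are shown below. What is called first, only, known or untested is meant among the compounds shown, and "the series" means these compounds.

Compound 2 `O=S(=O)(c1c[nH]c2ccc(Cl)cc12)C1CCNCC1` and compound 1 `CN1CCC(S(=O)(=O)c2c[nH]c3ccc(Cl)cc23)CC1` share one core; compound 3 `Cc1[nH]c2ccc(F)cc2c1SC1CCNCC1` and compound 4 `Cc1[nH]c2ccc(F)cc2c1SC1CCN(C)CC1` share another. The difference between the two cores is not broken down here. In a functional assay on the whole organism with Mus musculus as the target, in the writhing test (a higher number here means that more compound is needed for the effect, a lower number that less compound is needed), compound 2 gives 12.5 mg/kg, compound 1 gives 5.4 mg/kg and compound 3 gives 5.9 mg/kg. The change methyl in place of hydrogen on an amine nitrogen in a ring made a step of a 2.3-fold lower number from compound 2 to compound 1 (0.36 log units; beyond the scatter). The same change recurs as methyl in place of hydrogen on an amine nitrogen in a ring on the second core, so it occurs twice among these compounds. Compound 3 and compound 1 lie within the scatter of each other. Within the data shown here, for compound 4 in this assay a step of a 2.0-fold lower number from compound 3 to compound 4 (0.29 log units; within the scatter) is expected, about the size of the earlier one, because a 2.3-fold lower number from compound 2 to compound 1 (0.36 log units; beyond the scatter) is the only precedent and compound 3 starts from 5.9 mg/kg. Compound 4 is therefore estimated at 3 mg/kg, with a range from 1.3 mg/kg to 7 mg/kg.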

Compound 4, dose for half-maximal effect: 35.6 mg/kg
Compound 4: middle estimate off by 12-fold (1.07 log units), on the low side, outside the stated range (above it).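

In this assay methyl in place of hydrogen on the ring amine nitrogen gives a 6.0-fold higher number from compound 3 to compound 4 (0.78 log units; beyond the scatter), which runs opposite to the step seen on the core of compound 1. The two steps disagree: the same change on two cores in this assay, a 2.3-fold lower number (0.36 log units; beyond the scatter) from compound 2 to compound 1 and a 6.0-fold higher number (0.78 log units; beyond the scatter) from compound 3 to compound 4, 14-fold (1.15 log units) apart, beyond the scatter of two such steps The change therefore does not carry over between these two cores as a fixed step, but two pairs show only that its outcome depends on the core, not which of the differences between the cores decides it.

Going by these compounds, whether an ethyl or benzyl group on the same nitrogen would follow either direction remains open. Also open, on these data alone, is how the step would behave on a core differing from either of these in one place only.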